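Benzyl for Cyclohexyl on an Aromatic Nitrogen, Second Instance

This account rests on a few compounds, and the source may have more. Where it says the series, first, only, none or still open, it means among the compounds named here.

Compound 1, `O=Cc1ccc(-c2cn3ccnc3c(-c3ccc4ncn(C5CCCCC5)c4c3)n2)cc1`: 19%
Compound 2, `O=Cc1ccc(-c2cn3ccnc3c(-c3ccc4ncn(Cc5ccccc5)c4c3)n2)cc1`: 19%
Compound 3, `c1cn2cc(-c3ccc4c(c3)ncn4C3CCCCC3)nc(-c3ccc4ncn(C5CCCCC5)c4c3)c2n1`: 45%

In a functional assay on PC-3 cells (Homo sapiens) for inhibition, read by sulforhodamine B assay, with a stated time of 48 h, tested at 10 uM (a higher number here means more inhibition at the concentration tested (going by the name of the read-out), a lower number less inhibition), compound 1 gives 19%, and in this assay compound 2 gives 19%. The two differ only by benzyl in place of cyclohexyl on an aromatic nitrogen, and that change made no change at the digits printed from compound 1 to compound 2 (within the scatter). Compound 3 stands highest of the three measured numbers, beyond the scatter from both compound 1 and compound 2; how its core differs from the core of compound 1 is not broken down here.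

Compound 4, `c1ccc(Cn2cnc3ccc(-c4nc(-c5ccc6c(c5)ncn6C5CCCCC5)cn5ccnc45)cc32)cc1`, has not been measured. It differs from compound 3 by benzyl in place of cyclohexyl on an aromatic nitrogen, the same change at the same kind of place as that from compound 1 to compound 2. Resting on no change at the digits printed from compound 1 to compound 2 (within the scatter), compound 4 is expected to show a step of a number 2 percentage points lower from compound 3 to compound 4 (within the scatter), a shift that stays within the scatter. Compound 4 is therefore expected to give about 43% in this assay, most likely between 25% and 60%. Whether this second instance of the change behaves like the first is what the measurement will show.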

Compound 4, a percentage reported as inhibition, at one concentration (the size of the read-out at that concentration, not a potency): -39.5%
Compound 4: middle estimate off by 82.5 percentage points, on the high side; measured number outside the range, below it.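

Benzyl in place of cyclohexyl on an aromatic nitrogen gave, in this assay, a number 84.5 percentage points lower from compound 3 to compound 4 (beyond the scatter). Set beside the earlier instance, the result shows that the outcome of this change did not carry from one core to the other: the same change on two cores in this assay, no change at the digits printed (within the scatter) from compound 1 to compound 2 and a number 84.5 percentage points lower (beyond the scatter) from compound 3 to compound 4, 84.5 percentage points apart, beyond the scatter of two such steps. Within the data shown here, it does not show why the two cores differ, and with only two pairs it gives no rule for the series, neither that the change is harmless nor that it is generally harmful.

The compounds shown leave open whether the large step would recur on a third core, or with other groups on that nitrogen, such as a longer carbon chain or a chain ending in an amine. They also leave open how the negative number for compound 4, -39.5%, would compare at concentrations other than the single one tested.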